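The source may hold more compounds than are shown below. What is called first, only, known or untested is meant among the compounds shown, and "the series" means these compounds.

Compound 1 `Oc1ccc(CNc2cc(C(F)(F)F)cc3[nH]ncc23)cc1` is examined in an assay for inhibition of Tryptophan 2,3-dioxygenase (Homo sapiens), with stated times of 10 min and 60 min (a lower number here means a stronger inhibitor, a higher number a weaker inhibitor), where compound 1 gives 2550 nM. Of the two numbers available, that of compound 1 is the upper one, but its nearest neighbour, compound 2 `O=[N+]([O-])c1ccc(CNc2cc(Br)cc3[nH]ncc23)cc1`, gives 2230 nM in this assay, and the gap between them lies within the usual scatter, so the two are read as equivalent. Compound 3 `OC1CCCC(Nc2cccc(CNc3cc(C(F)(F)F)cc4[nH]ncc34)c2)C1` returns only > 100000 nM in this assay, which is a limit of the assay and not a number. That entry is the limit of > 100000 nM in this assay, at which 1 of the 3 values shown sits. Compound 4 `FC(F)(F)c1cc(NC[C@@H]2CCCCN2)c2cn[nH]c2c1` differs from compound 1 in a single place: piperidin-2-yl in place of 4-hydroxyphenyl on a saturated chain carbon bound to a nitrogen on an aromatic ring. Among the measured compounds shown here, no measured pair of compounds shows a change of this kind, so the size of the step rests on the spread of the values seen. The expected step in this assay is a 2.4-fold higher number from compound 1 to compound 4 (0.37 log units; beyond the scatter), a modest move toward a weaker inhibitor, with wide uncertainty. Compound 4 is estimated at 6000 nM in this assay, within 1200 nM to 40000 nM.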

Compound 4, half-maximal inhibitory concentration: 8050 nM
Compound 4: the middle estimate sits 1.3-fold (0.13 log units) below what was measured, within the range that was stated.
By their numbers in this assay, from the lowest: compounds 2 and 1 (each within the scatter of the next); then compound 4. At a limit, above all of these: compound 3.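

At the saturated chain carbon bound to a nitrogen on an aromatic ring, piperidin-2-yl in place of 4-hydroxyphenyl gives a 3.2-fold higher number from compound 1 to compound 4 (0.50 log units; beyond the scatter) in this assay. This place therefore still yields a measured number, not a limit, when a six-membered aromatic ring of carbon only gives way to a six-membered non-aromatic ring with a hetero atom, and the cost of the change is modest. Nothing measured here gives a cause for this step.

With one pair at this place, the compounds shown do not separate the loss of the aromatic ring from the entry of the ring nitrogen, nor show what the defined stereocentre of compound 4 contributes. A cyclohexyl group, a pyridinyl ring or the mirror-image piperidin-2-yl group would bear on those questions.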